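The compounds below may be only part of what the source reports. "The series", "measured", "known", "first", "only" and "open" are said of these compounds alone.

Working notes on the series. Going by the values given here, in an assay on CHO cells for displacement of a labelled ligand from adenosine receptor A1 (Homo sapiens) (on this read-out lower numbers stand for stronger inhibition and higher numbers for weaker inhibition), compound 2 `CCNC(=O)[C@H]1O[C@@H](n2cnc3c(NNC(=O)c4sccc4C)nc(Cl)nc32)[C@H](O)[C@@H]1O` gives 1600 nM, the only number in the set. Compound 1 `CCNC(=O)[C@H]1O[C@@H](n2cnc3c(NNC(=O)c4ccccc4)nc(Cl)nc32)[C@H](O)[C@@H]1O` reaches only a limit of this assay, > 5000 nM. One step is known, an at least 3.1-fold lower number from compound 1 to compound 2 (0.49 log units; beyond the scatter), and it starts from the limit (the limit of > 5000 nM in this assay, at which 1 of the 2 values shown sits). Compound 3 `CCNC(=O)[C@H]1O[C@@H](n2cnc3c(NNC(=O)c4ccc[nH]4)nc(Cl)nc32)[C@H](O)[C@@H]1O` carries 1H-pyrrol-2-yl in place of 3-methylthiophen-2-yl on a carbonyl carbon. Among the compounds with values here, no measured step matches this change; the one known step shows only that 3-methylthiophen-2-yl brings a number where phenyl does not. A modest loss is expected for compound 3, a 1.9-fold higher number from compound 2 to compound 3 (0.27 log units; within the scatter), so the estimate for compound 3 is 3000 nM, within a range from 1000 nM to 10000 nM.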

Compound 3, inhibition constant: 610 nM
Compound 3: middle estimate off by 4.9-fold (0.69 log units), on the high side, and the stated range ends above it.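

In this assay the group on the carbonyl carbon needs neither sulfur nor a methyl to give a measured number: 1H-pyrrol-2-yl in place of 3-methylthiophen-2-yl gives a 2.6-fold lower number from compound 2 to compound 3 (0.42 log units; beyond the scatter) in this series. Replacing phenyl with 1H-pyrrol-2-yl gives an at least 8.1-fold lower number from compound 1 to compound 3 (0.91 log units; beyond the scatter) but that step starts from a limit and gives only a bound: the limit of > 5000 nM in this assay, at which 1 of the 3 values shown sits.

On these data alone, whether the lower number goes with the ring hydrogen-bond donor, the missing methyl or the change from sulfur to nitrogen stays open. The 1-methylpyrrol-2-yl and unsubstituted thiophen-2-yl groups would separate these.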